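Cytotoxicity of a Sulfonyl Ring Swapped for 2-Methoxyphenyl

The source may report more compounds than this note shows. Statements on the series, on what has been measured and on what is new or still open speak of the compounds shown alone.

Compound 1 `Oc1c(-c2nnc(Cc3ccc(Cl)cc3)[nH]2)ncc2cccnc12`: 31600 nM
Compound 2 `O=C(NCc1ccc(Cl)cc1)c1ncc2cccnc2c1O`: > 50100 nM
Compound 3 `Cc1n[nH]c(-c2ncc3c(N4CCCCS4(=O)=O)ccnc3c2O)n1`: > 50100 nM

These values come from a toxicity assay on THP-1 cells (Homo sapiens) for cytotoxicity; on this read-out higher numbers stand for an effect only at larger amounts of compound and lower numbers for an effect already at smaller amounts. Compound 3 gives > 50100 nM, which is a limit of the assay and not a number. Compound 2 gives > 50100 nM, which is also a limit. Most of the readings so far share one mark: the limit of > 50100 nM in this assay, at which 2 of the 3 values shown sit. Only compound 1 has a true number, 31600 nM.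

Compound 4 `COc1ccccc1-c1ccnc2c(O)c(-c3nc(C)n[nH]3)ncc12` differs from compound 3 in one place: a group of 8 heavy atoms (7 carbon, 1 oxygen; one six-membered aromatic ring of carbon only) in place of a group of 8 heavy atoms (4 carbon, 1 nitrogen, 2 oxygen, 1 sulfur; one six-membered non-aromatic ring with 2 hetero atoms), on an aromatic carbon. The 2-methoxyphenyl sits opposite the ring nitrogen.

Within the data shown here, no measured step shows what such a swap does in this assay, so the expectation rests on little. Among the measured compounds shown here, with compound 1 at 31600 nM as the only guide, a small move toward lower numbers is expected, and no change at all remains possible. The estimated step is an at least 1.7-fold lower number from compound 3 to compound 4 (0.25 log units; that floor lies within the scatter). For compound 4 the expected value is 28000 nM. The estimated range for compound 4 runs from 9000 nM to 50100 nM.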

Compound 4, half-maximal effective concentration in the THP-1 assay: > 50100 nM
Compound 4: only a limit was reported; the forecaster's own chance of this, stated with the estimate: 45%; middle value at least 1.7-fold (0.25 log units) away from the limit.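

In the THP-1 assay compound 3 gives > 50100 nM, which is a limit of the assay and not a number. In the THP-1 assay compound 4 gives > 50100 nM, which is also a limit of the assay and not a number. In a physicochemical assay for solubility, measured as kinetic solubility (a higher number here means a more soluble compound, a lower number a less soluble compound), compound 3 gives 250000 nM. In the physicochemical assay compound 4 gives > 250000 nM, which is a limit of the assay and not a number. Neither of the two steps between these compounds can be read. The compounds shown leave open whether swapping in the 2-methoxyphenyl changes cytotoxicity at all.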